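Swapping a Nitrile for Methoxy on a Benzamide Series

The compounds below may be only part of what the source reports. "The series", "measured", "known", "first", "only" and "open" are said of these compounds alone.

Compound 1, `Cc1cccc(C(=O)N2CCCC(C(=O)Nc3ccc(Cl)cc3)C2)c1`, gives 0%.
Compound 2, `CSc1cccc(C(=O)N2CCCC(C(=O)Nc3ccc(Cl)cc3)C2)c1`, gives 0%.
Compound 3, `N#Cc1cccc(C(=O)N2CCCC(C(=O)Nc3ccc(Cl)cc3)C2)c1`, gives 0%.

All three compounds were tested in an ADME assay on PC-3 cells (Homo sapiens) for cytotoxicity, read by WST assay, tested at 100 uM; on this read-out lower numbers stand for less inhibition and higher numbers for more inhibition at the one concentration tested (going by the name of the read-out). They share one core and differ only in the group carried on an aromatic carbon of the benzamide ring: methyl in compound 1, methylsulfanyl in compound 2 and cyano in compound 3. Compound 3 stands level with compound 1 and compound 2, none of the three showing any measurable inhibition.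

Compound 4, `COc1cccc(C(=O)N2CCCC(C(=O)Nc3ccc(Cl)cc3)C2)c1`, is the next member of the series and has not yet been measured. It differs from compound 3 as follows: methoxy in place of cyano on an aromatic carbon.

Going by the values given here, three steps bear on this change, since each swaps one small group for another at the same aromatic carbon: no change at the digits printed from compound 1 to compound 3 (within the scatter), no change at the digits printed from compound 2 to compound 3 (within the scatter) and no change at the digits printed from compound 1 to compound 2 (within the scatter). None of them moved the read-out beyond the scatter. Methoxy is a fourth small group at the same position, so the step of no change at the digits printed from compound 3 to compound 4 (within the scatter) is expected to show no change beyond the scatter. Compound 4 is therefore estimated at 0%, within a range from 0% to 10%.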

Compound 4, a percentage reported as inhibition, at one concentration (the size of the read-out at that concentration, not a potency): 0%
Beside the measured number, compound 4's estimate shows no gap at the digits printed, within the range that was stated.
By their numbers in this assay, from the lowest: compounds 1, 2, 3 and 4 (each within the scatter of the next).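

Going from cyano to methoxy leaves this assay with no change at the digits printed from compound 3 to compound 4 (within the scatter) and the two other swaps to methoxy read no change at the digits printed from compound 2 to compound 4 (within the scatter) and no change at the digits printed from compound 1 to compound 4 (within the scatter) at this same aromatic carbon. The position has now carried four small groups, joined to the ring through carbon, sulfur or oxygen, and the choice among them has not moved this read-out beyond the scatter. Nothing measured here explains why the read-out stays flat across these four compounds.

On these data alone, whether a different kind of group at this carbon, such as an amine, a carboxylic acid or a longer alkyl chain, would give a reading that stands apart from these four remains open. Equally open, as far as these compounds go, is what a change elsewhere on the shared core would do, for all four compounds differ at this one carbon only.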